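The source may report more compounds than this note shows. Statements on the series, on what has been measured and on what is new or still open speak of the compounds shown alone.

Measured so far in a functional assay (brain) for inhibition, with Rattus norvegicus as the target; on this read-out lower numbers stand for stronger inhibition and higher numbers for weaker inhibition:
- compound 1 `Cc1c(C)c2c(c(C)c1O)CCC(C)(C(=O)N1CCN(c3cc(N4CCCC4)nc(N4CCCC4)n3)CC1)O2`: 500 nM
- compound 2 `CC(=O)Oc1c(C)c(C)c2c(c1C)CCC(C)(C(=O)N1CCN(c3cc(N4CCCC4)nc(N4CCCC4)n3)CC1)O2`: 17000 nM
- compound 3 `CCNc1cccnc1N1CCN(C(=O)C2(C)CCc3c(C)c(O)c(C)c(C)c3O2)CC1`: 12000 nM

Compound 3 stands second highest of the three numbers in this assay. Its nearest neighbour is compound 2, whose value lies within the scatter of that of compound 3; the furthest is compound 1, which gives a number well below that of compound 3, beyond the scatter. Compound 1 and compound 3 share the core and the amide-linked ring; they differ only in the aromatic group on the ring nitrogen, and the two values show that this group alone moves the read-out a great deal.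

Compound 4 `Cc1c(C)c2c(c(C)c1O)CCC(C)(C(=O)N1CCN(c3ccc(Cl)cc3)CC1)O2` is not yet measured. It differs from compound 3 by 4-chlorophenyl in place of 3-(ethylamino)pyridin-2-yl on an amine nitrogen in a ring.

Among the compounds with values here, the only measured step, a 34-fold higher number from compound 1 to compound 2 (1.53 log units; beyond the scatter), concerns the acetyl on the phenolic oxygen and does not touch the group exchanged here, so it offers no guide. The pair compound 1 / compound 3 shows that changes of the aromatic group on the ring nitrogen can be large in either direction, without saying which way a 4-chlorophenyl goes. The expected step is therefore a 2.0-fold lower number from compound 3 to compound 4 (0.30 log units; within the scatter), with wide uncertainty. Compound 4 is estimated at 6000 nM in this assay, in a range from 1000 nM to 30000 nM.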

Compound 4, half-maximal inhibitory concentration: 800 nM
Compound 4: the middle estimate sits 7.5-fold (0.88 log units) above what was measured; measured number below the stated range.
By their numbers in this assay, from the lowest: compounds 1 and 4 (each within the scatter of the next); then compounds 3 and 2 (each within the scatter of the next).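

In this assay, the exchange of 3-(ethylamino)pyridin-2-yl for 4-chlorophenyl on the amine nitrogen in the ring, with the shared core unchanged, is a large step in the favourable direction (a 15-fold lower number from compound 3 to compound 4 (1.18 log units; beyond the scatter)), so a number in the range of compound 1 does not require the aromatic group of compound 1 at this position. Compound 4 gives 800 nM and compound 1 gives 500 nM, two values within the scatter of each other, even though the entering 4-chlorophenyl has no hydrogen-bond donor or acceptor and contains no hetero atom in its ring. No supporting measurement is available to explain a step of this size.

The compounds shown do not separate the contribution of the chlorine from that of the carbon ring, which a plain phenyl or a phenyl bearing methoxy or trifluoromethyl in place of the chlorine would address, nor do they separate the ring nitrogen of the leaving group from its ethylamino chain. They also leave open whether an acetyl on the phenolic oxygen would change the number of compound 4 as strongly as it does for the compound 1 pair (a 34-fold higher number from compound 1 to compound 2 (1.53 log units; beyond the scatter)).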